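Aryl ether variation on a macrolide core

The source may hold more compounds than are shown below. What is called first, only, known or untested is meant among the compounds shown, and "the series" means these compounds.

Compound 1 `CC[C@@H]1/C=C(\C)C[C@H](C)C[C@H](OC)[C@H]2O[C@@](O)(C(=O)C(=O)N3CCCC[C@H]3C(=O)O[C@H](/C(C)=C/[C@@H]3CC[C@@H](Oc4cccc(C)c4)[C@H](OC)C3)[C@H](C)[C@@H](O)CC1=O)[C@H](C)C[C@@H]2OC` is a macrolide carrying a 3-methylphenyl group on an oxygen on a saturated carbon. In a functional assay on cells for inhibition, with Murine T-cell line (Mus musculus) as the target (on this read-out lower numbers stand for stronger inhibition and higher numbers for weaker inhibition), compound 1 gives 5.4 nM, which is the higher of the two numbers recorded so far. Its closest neighbour is compound 2 `CC[C@@H]1/C=C(\C)C[C@H](C)C[C@H](OC)[C@H]2O[C@@](O)(C(=O)C(=O)N3CCCC[C@H]3C(=O)O[C@H](/C(C)=C/[C@@H]3CC[C@@H](Oc4ccc(F)cc4)[C@H](OC)C3)[C@H](C)[C@@H](O)CC1=O)[C@H](C)C[C@@H]2OC`, the 4-fluorophenyl analogue, which in this assay gives 3.4 nM; the step of a 1.6-fold lower number from compound 1 to compound 2 (0.20 log units; within the scatter) lies within the scatter, so the two values cannot be told apart. Compound 3 `CC[C@@H]1/C=C(\C)C[C@H](C)C[C@H](OC)[C@H]2O[C@@](O)(C(=O)C(=O)N3CCCC[C@H]3C(=O)O[C@H](/C(C)=C/[C@@H]3CC[C@@H](Oc4ccc(OC)cc4)[C@H](OC)C3)[C@H](C)[C@@H](O)CC1=O)[C@H](C)C[C@@H]2OC` has not yet been measured; it differs from compound 1 as follows: 4-methoxyphenyl in place of 3-methylphenyl on an oxygen on a saturated carbon. For the measured compounds named here, the only measured step bearing on this change is the aryl swap from compound 1 to compound 2, and that step was within the scatter. For compound 3 no step beyond the scatter is therefore expected, with a 1.1-fold lower number from compound 1 to compound 3 (0.03 log units; within the scatter) as the expected change. Compound 3 is estimated at 5 nM, with a range from 2 nM to 12 nM.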

Compound 3, half-maximal inhibitory concentration: 1.4 nM
Estimate against measurement, compound 3: 3.6-fold (0.55 log units) above; the whole stated range lies above it.
By their numbers in this assay, from the lowest: compound 3; then compounds 2 and 1 (each within the scatter of the next).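

The aryl group on this oxygen now proves able to shift the number in this assay: the step of a 3.9-fold lower number from compound 1 to compound 3 (0.59 log units; beyond the scatter) and the step of a 2.4-fold lower number from compound 2 to compound 3 (0.39 log units; beyond the scatter) both lie beyond the scatter, though both are modest, whereas the earlier pair could not be told apart. Compound 3 therefore stands apart from both earlier compounds, and the 4-methoxyphenyl group is the only aryl group shown that separates from the others. No measurement is available that explains this difference.

Because compound 1 and compound 3 differ in both the substituent and its placement, it remains open whether the methoxy group or its placement matters more, as neither 3-methoxyphenyl nor 4-methylphenyl is among the compounds shown. On these data alone, whether a longer ether such as 4-ethoxyphenyl or an amine such as 4-dimethylaminophenyl would follow compound 3 also remains open.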